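The compounds below may be only part of what the source reports. "The series", "measured", "known", "first", "only" and "open" are said of these compounds alone.

In an ADME assay on MDCK cells (Canis lupus familiaris) for cytotoxicity, read by MTT assay (a higher number here means that more compound is tolerated, a lower number that less compound is tolerated), the three measured compounds stand as follows:

Compound 1 `O=c1cc(-c2cccc(Cl)c2)oc2ccccc12` gives 174000 nM.
Compound 2 `O=C1/C(=C/c2ccccc2Cl)Oc2ccccc21` gives 339000 nM.
Compound 3 `O=C1/C(=C/c2cccc(Cl)c2)Oc2ccccc21` gives 26900 nM.

Compound 3 has the lowest number of the three. Its nearest neighbour is compound 1, whose value lies higher by a gap beyond the scatter, and compound 2 lies further away still, also beyond the scatter.

Compound 4 `O=C1/C(=C/c2cccc([N+](=O)[O-])c2)Oc2ccccc21` has not yet been measured. It differs from compound 3 in one place: nitro in place of chloro on an aromatic carbon. Among the compounds with values here, no pair of measured compounds shares this change, so the data give no direction for it. In this assay a step of no more than the scatter is expected, in either direction. Compound 4 is expected to give about 30000 nM, within 8000 nM to 120000 nM. That amounts to an expected step of a 1.1-fold higher number from compound 3 to compound 4 (0.05 log units; within the scatter).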

Compound 4, half-maximal cytotoxic concentration: 396000 nM
The estimate for compound 4 lay 13-fold (1.12 log units) below the measured number; measured number above the stated range.
By their numbers in this assay, from the lowest: compound 3; then compounds 1, 2 and 4 (each within the scatter of the next, the first and the last beyond it).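

Within the data shown here, in (this assay), the only step that can be read at this position shows that the group on this aromatic carbon, meta to a large group, matters greatly: nitro in place of chloro gives a 15-fold higher number from compound 3 to compound 4 (1.17 log units; beyond the scatter) on the shared core. The low number of compound 3 therefore does not carry over to compound 4. Nothing measured here explains the step.

From the compounds shown here alone, whether an amine or a carboxylic acid at this place would stay near compound 3 or compound 4 remains open. Also open, going by these compounds, is whether nitro would give a similar step on the core of compound 1 or at the chloro position of compound 2.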